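The source may report more compounds than this note shows. Statements on the series, on what has been measured and on what is new or still open speak of the compounds shown alone.

Compound 2 `c1csc(-c2ccccc2OCC2=NCCN2)c1` stands lowest of the two numbers in a functional assay for activation of Alpha-1A adrenergic receptor (Homo sapiens), read by calcium flux (a lower number here means that less compound is needed, a higher number that more compound is needed for the effect), with compound 2 at 1 nM; in this assay compound 1 `c1ccc(-c2cnccn2)c(OCC2=NCCN2)c1` gives 2.51 nM. Within the data shown here, the one measured step, a 2.5-fold lower number from compound 1 to compound 2 (0.40 log units; beyond the scatter), bears on the next change. Compound 3 `c1ccc(-c2ncc[nH]2)c(OCC2=NCCN2)c1` differs from compound 2 by 1H-imidazol-2-yl in place of thiophen-2-yl on an aromatic carbon. Since the move toward thiophen-2-yl gave the lower number, returning to a five-membered ring with two hetero atoms is expected to give a modestly higher number, near compound 1. The step expected is a 3.0-fold higher number from compound 2 to compound 3 (0.48 log units; beyond the scatter). For compound 3 the estimate is 3 nM, ranging from 1 nM to 10 nM.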

Compound 3, half-maximal effective concentration: 100 nM
Compound 3: the middle estimate sits 33-fold (1.52 log units) below what was measured, outside the stated range (above it).
By their numbers in this assay, from the lowest: compound 2; then compound 1; then compound 3.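

Position tolerance is far narrower than the first swap suggested: 1H-imidazol-2-yl in place of thiophen-2-yl gives a 100-fold higher number from compound 2 to compound 3 (2.00 log units; beyond the scatter) and in place of pyrazin-2-yl gives a 40-fold higher number from compound 1 to compound 3 (1.60 log units; beyond the scatter) as well. Aromatic ring size alone therefore does not set the number here, since compound 2 and compound 3 both carry five-membered rings. No supporting data on hand explain the size of these steps.

Still open, as far as these compounds go, is whether a methyl group on the ring nitrogen of 1H-imidazol-2-yl would restore the lower numbers. From the compounds shown here alone, how a plain phenyl ring would compare at this place also remains unknown.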